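The source may hold more compounds than are shown below. What is called first, only, known or untested is meant among the compounds shown, and "the series" means these compounds.

Measured compounds:
compound 1 `Nc1ncnc2c1ncn2[C@@H]1O[C@H](CNCc2ccc(OCC(=O)Nc3ccccn3)cc2)[C@@H](O)[C@H]1O` — 54900 nM
compound 2 `Nc1ncnc2c1ncn2[C@@H]1O[C@H](C(=O)N2CCC[C@H]2C(=O)OCc2ccccc2)[C@@H](O)[C@H]1O` — 85300 nM

In an assay for inhibition of histone-lysine N-methyltransferase, H3 lysine-79 specific (Homo sapiens), read by scintillation counting, with a stated time of 1 h, in the presence of a further agent that is not named here (a higher number here means a weaker inhibitor, a lower number a stronger inhibitor), compound 1 gives 54900 nM, and compound 2 gives 85300 nM; the two numbers lie within the scatter of each other, so neither stands apart. Compound 3 `Nc1ncnc2c1ncn2[C@@H]1O[C@H](CNCc2ccc(OCC(=O)Nc3nccs3)cc2)[C@@H](O)[C@H]1O` differs from compound 1 in one place: 1,3-thiazol-2-yl in place of pyridin-2-yl on an amide-type nitrogen. For the measured compounds named here, no measured pair shows this change, so its effect rests on expectation alone. The step of a 1.0-fold higher number from compound 1 to compound 3 (0.00 log units; within the scatter) is expected to stay within the scatter, in no clear direction. Compound 3 is estimated at 55000 nM, with a range from 15000 nM to 160000 nM.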

Compound 3, half-maximal inhibitory concentration: 90400 nM
Compound 3: middle estimate off by 1.6-fold (0.22 log units), on the low side, and the stated range covers the measured number.
By their numbers in this assay, from the lowest: compounds 1, 2 and 3 (each within the scatter of the next).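

In this assay, for the compounds shown here, 1,3-thiazol-2-yl in place of pyridin-2-yl on an amide-type nitrogen gives a 1.6-fold higher number from compound 1 to compound 3 (0.22 log units; within the scatter), the first measured step at this position. The five-membered aromatic ring and the six-membered one therefore cannot be told apart here, and both compounds remain weak inhibitors. Nothing measured here bears on the reason for this result. The compounds shown leave open whether a different group on this amide-type nitrogen, such as phenyl, methyl or a longer chain, would move the number beyond the scatter in either direction.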